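The source may hold more compounds than are shown below. What is called first, only, known or untested is meant among the compounds shown, and "the series" means these compounds.

Among the compounds with values here, compound 1 `CSc1ccc2nc(C)cc(OCC(=O)Nc3cc(C)cc(C)c3)c2c1` is the first measured compound; in a toxicity assay on HepG2 cells (Homo sapiens) for inhibition, read by CellTiter-Glo, with a stated time of 48 h (on this read-out lower numbers stand for stronger inhibition and higher numbers for weaker inhibition), compound 1 gives > 100000 nM, which is a limit of the assay rather than a number.
Compound 2 `CCOc1ccc2nc(C)cc(OCC(=O)Nc3cc(C)cc(C)c3)c2c1` is the second; in this assay compound 2 gives > 100000 nM, again a limit.
Compound 3 `COc1ccc(NC(=O)COc2cc(C)nc3ccc(OC)cc23)cc1` is the third; in this assay compound 3 gives > 100000 nM, again a limit.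

All three measured values sit at one and the same limit (the limit of > 100000 nM in this assay, at which 3 of the 3 values shown sit). Within the data shown here, the single measured step, a step that the two limits leave unreadable from compound 1 to compound 2, cannot be given a size, since both of its ends are limits. Compound 3 therefore stands at the limit of this assay with no number attached, and nothing in the data ranks it against compound 1 or compound 2.

Compound 4 `COc1ccc2nc(C)cc(OCC(=O)Nc3ccncn3)c2c1` has not yet been measured. It differs from compound 3 in one place: pyrimidin-4-yl in place of 4-methoxyphenyl on an amide-type nitrogen. Among the measured compounds shown here, no measured step touches the amide-type nitrogen; the only step on record concerns a different part of the shared core and is itself unreadable. There is thus no measured basis for expecting a change in either direction. Compound 4 is expected to stay at the limit as well, estimated at 150000 nM with a range from 50000 nM to 500000 nM. The step from compound 3 to compound 4 is accordingly expected to be a step that the limit leaves unreadable from compound 3 to compound 4, none beyond the scatter.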

Compound 4, half-maximal inhibitory concentration: > 100000 nM
Compound 4 was reported as a limit; the forecaster's own chance of this, stated with the estimate: 80%; the middle value does not contradict the limit.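

In this assay compound 4 gives > 100000 nM, a limit and not a number. No size can be read for the step between compound 3 and compound 4, because both ends are limits: the limit of > 100000 nM in this assay, at which 4 of the 4 values shown sit. The compounds shown leave open whether any change on the shared core or on the amide-type nitrogen would bring inhibition to a measurable number.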